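This account rests on a few compounds, and the source may have more. Where it says the series, first, only, none or still open, it means among the compounds named here.

Measured in a functional assay on A549 cells (Homo sapiens) for cytotoxicity, read by MTT assay, with a stated time of 72 h; on this read-out higher numbers stand for weaker inhibition and lower numbers for stronger inhibition:
Compound 1 `COc1ccc(OC)c(/C=C/C(=O)Nc2cc3c(Nc4ccc(F)c(Cl)c4)ncnc3cc2OC)c1`: 11200 nM
Compound 2 `COc1ccc(OC)c(/C=C/C(=O)Nc2cc3c(Nc4ccc(F)c(Cl)c4)ncnc3cc2O[C@H]2CCOC2)c1`: 7300 nM

Within the data shown here, compound 2 stands level with compound 1, the only other compound measured, and the two differ only by a 1.5-fold lower number from compound 1 to compound 2 (0.19 log units; within the scatter). Compound 3 `O=C(/C=C/c1ccc(F)cc1Cl)Nc1cc2c(Nc3ccc(F)c(Cl)c3)ncnc2cc1O[C@H]1CCOC1` carries one change from compound 2: 2-chloro-4-fluorophenyl in place of 2,5-dimethoxyphenyl on a double-bonded chain carbon bound to a double-bonded chain carbon. That step swaps a different group, so it says nothing direct about 2-chloro-4-fluorophenyl in place of 2,5-dimethoxyphenyl. Among the measured compounds shown here, no measured step bears on this change, so no shift beyond the scatter is expected in this assay. The expected result is a 1.5-fold lower number from compound 2 to compound 3 (0.16 log units; within the scatter). For compound 3 the estimate is 5000 nM, with an expected range from 1500 nM to 15000 nM.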

Compound 3, half-maximal inhibitory concentration: 5190 nM
Beside the measured number, compound 3's estimate is 1.0-fold (0.02 log units) below it, within the range that was stated.
By their numbers in this assay, from the lowest: compounds 3, 2 and 1 (each within the scatter of the next, the first and the last beyond it).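

Among these compounds, the step from the dimethoxy aryl group to the halogenated one, a 1.4-fold lower number from compound 2 to compound 3 (0.15 log units; within the scatter) in this assay, is the first look at this position on a double-bonded chain carbon bound to a double-bonded chain carbon. Exchanging 2,5-dimethoxyphenyl, with 2 hydrogen-bond acceptors, for 2-chloro-4-fluorophenyl, with 0, leaves the read-out within the scatter. No available data account for this result. On these data alone, whether an unsubstituted phenyl or a dimethylaminomethyl group in this place would shift the number beyond the scatter remains open.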